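The source may hold more compounds than are shown below. What is called first, only, known or untested is meant among the compounds shown, and "the series" means these compounds.

Working notes on the series around the shared core of compound 1 `COc1ccc(S(=O)(=O)N2CCc3cccc(NC(=O)Oc4ccccc4)c32)cc1`, read in a functional assay on KB cells (Homo sapiens) for cytotoxicity; a lower number here means a stronger inhibitor, a higher number a weaker inhibitor. Compound 1 gives > 10000 nM, which is a limit of the assay and not a number. Compound 2 `COc1ccc(S(=O)(=O)N2CCc3cccc(NC(C)=O)c32)cc1` gives 89 nM. Compound 3 `COc1ccc(S(=O)(=O)N2CCc3cccc(NC(=O)c4ccccc4)c32)cc1` gives 297 nM, the higher of the two actual numbers in the set.

The next change leads to compound 4 `COc1ccc(S(=O)(=O)N2CCc3cccc(NC(=O)c4ccc(C#N)cc4)c32)cc1`: cyano in place of hydrogen on an aromatic carbon, para to a large group.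

Within the data shown here, no measured step alters a substituent on this phenyl ring, so the evidence is indirect. The two large steps, an at least 110-fold lower number from compound 1 to compound 2 (2.05 log units; beyond the scatter) and an at least 33-fold lower number from compound 1 to compound 3 (1.52 log units; beyond the scatter), both remove the phenoxy group on the carbonyl carbon and start from a limit, so they say little about this change. The closest guide is the modest step of a 3.3-fold higher number from compound 2 to compound 3 (0.52 log units; beyond the scatter), where phenyl replaces methyl on the same carbonyl carbon.

A small change is therefore expected in this assay, within the scatter and leaning toward a higher number. The estimated step runs a 1.4-fold higher number from compound 3 to compound 4 (0.15 log units; within the scatter). For compound 4 the expected value is 420 nM, with an estimated range of 120 nM to 1500 nM.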

Compound 4, half-maximal inhibitory concentration: 105 nM
For compound 4 the middle estimate is 4.0-fold (0.60 log units) above the measured one; measured number below the stated range.
By their numbers in this assay, from the lowest: compounds 2 and 4 (each within the scatter of the next); then compound 3. At a limit, above all of these: compound 1.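

In this assay, among these compounds, a 2.8-fold lower number from compound 3 to compound 4 (0.45 log units; beyond the scatter), the first measured change on this phenyl ring: cyano in place of hydrogen, para to a large group, moves the number beyond the scatter, so substitution at this position is not silent. With the nitrile in place, a 1.2-fold higher number from compound 2 to compound 4 (0.07 log units; within the scatter), so the gap seen between phenyl and methyl on the carbonyl carbon does not appear between 4-cyanophenyl and methyl, and a larger group on that carbon is compatible with a value in the range of compound 2. Compound 1 remains a limit of the assay and not a number, so an at least 95-fold lower number from compound 1 to compound 4 (1.97 log units; beyond the scatter) gives a bound and not a size: the limit of > 10000 nM in this assay, at which 1 of the 4 values shown sits.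

The compounds shown leave open whether the shift belongs to the nitrile itself or would also follow from another group at the same place, such as an amine, a carboxylic acid, a chlorine atom or a longer chain. They also leave open how a nitrile elsewhere on the ring would read, and whether the same change carries over to the phenoxy carbonyl of compound 1.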